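One group exchanged on compound 3

The compounds below may be only part of what the source reports. "The series", "measured", "known", "first", "only" and "open" are said of these compounds alone.

Compound 1 `CC(O)(CSc1cccc(S(F)(F)(F)(F)F)c1)C(=O)Nc1ccc(C#N)cc1C(F)(F)F` gives 17600 nM
Compound 2 `CC(O)(CSc1ccc(S(F)(F)(F)(F)F)cc1)C(=O)Nc1ccc(S(F)(F)(F)(F)F)cc1` gives 18300 nM
Compound 3 `CC(O)(CSc1ccc(S(F)(F)(F)(F)F)cc1)C(=O)Nc1cccc(S(F)(F)(F)(F)F)c1` gives 12700 nM

In a functional assay on LNCaP cells (Homo sapiens) for antiproliferative activity, read by propidium iodide staining, with a stated time of 96 h (on this read-out higher numbers stand for weaker inhibition and lower numbers for stronger inhibition), compound 3 stands at 12700 nM and this value lies within the usual scatter of both other compounds, so the three cannot be ranked. Compound 4 `CC(O)(CSc1ccc(C(F)(F)F)cc1)C(=O)Nc1cccc(S(F)(F)(F)(F)F)c1` has not yet been measured. It differs from compound 3 in one place, with a group of 4 heavy atoms (1 carbon, 3 fluorine; no ring) in place of a group of 6 heavy atoms (5 fluorine, 1 sulfur; no ring), on an aromatic carbon as the counted difference. A trifluoromethyl group enters in place of a group with no common name, on an aromatic carbon.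

Among the measured compounds shown here, no measured pair differs in just one place, so nothing here sizes such a change directly. Compound 1 differs from compound 3 in more than one place, yet compound 1 at 17600 nM stays within the scatter of it. The expected change in this assay is therefore none beyond the scatter, in either direction. The estimate amounts to a 1.1-fold higher number from compound 3 to compound 4 (0.04 log units; within the scatter) as the expected step. Compound 4 is estimated at 14000 nM and is expected to fall from 7000 nM to 28000 nM in repeat measurements.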

Compound 4, half-maximal inhibitory concentration: 17500 nM
Estimate against measurement, compound 4: 1.3-fold (0.10 log units) below; measured number inside the range.
By their numbers in this assay, from the lowest: compounds 3, 4, 1 and 2 (each within the scatter of the next).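

Among the compounds shown here, this is the first pair in the set that differs in only one place, so it gives a direct reading of this exchange. In this assay, replacing the group with no common name by trifluoromethyl, on an aromatic carbon para to a large group, gives a 1.4-fold higher number from compound 3 to compound 4 (0.14 log units; within the scatter), so the two compounds cannot be told apart. At this position, then, the smaller count of heavy atoms in the trifluoromethyl group, and its carbon in place of sulfur, leave no effect that can be separated from the scatter. No measurement here offers an explanation for this result. From the compounds shown here alone, it remains open whether an amine or a carboxylic acid on this carbon would move the number beyond the scatter. Going by these compounds, the same exchange on the other aromatic ring is also open. One step cannot show whether the result holds elsewhere.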